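This account rests on a few compounds, and the source may have more. Where it says the series, first, only, none or still open, it means among the compounds named here.

Working notes on the series. Compound 1 `COC(=O)c1ccc2c(C(=O)c3ccccc3)cc(C(=O)c3ccccc3)c-2cc1` and compound 2 `O=C(O)c1ccc2c(C(=O)c3ccccc3)cc(C(=O)c3ccccc3)c-2cc1` share one core; compound 3 `COC(=O)c1ccc2c(C=O)cc(-c3ccccc3)c-2cc1` and compound 4 `O=Cc1cc(-c2ccccc2)c2ccc(C(=O)O)ccc1-2` share another, and the difference between the two cores is not broken down here. In an assay on cells for displacement of a labelled ligand from Orexin/Hypocretin receptor type 1 (Homo sapiens), read by scintillation counting, with stated times of 10 min and 90 min, tested at 10 uM (on this read-out higher numbers stand for more inhibition at the one concentration tested (going by the name of the read-out) and lower numbers for less inhibition), compound 1 gives -10.6%, and compound 2 gives -10.4%; the step of a number 0.2 percentage points higher from compound 1 to compound 2 (within the scatter) is made by hydrogen in place of methyl on an oxygen next to a carbonyl group. In this assay compound 3 gives 8.5%, the highest of the three numbers. Compound 4 is made from compound 3 by the same change, (hydrogen in place of methyl on an oxygen next to a carbonyl group), at the same place. Because the step of a number 0.2 percentage points higher from compound 1 to compound 2 (within the scatter) lies within the scatter, the expected step is likewise small, no change at the digits printed from compound 3 to compound 4 (within the scatter). For compound 4 the estimate in this assay is 8.5%, with a range from -6% to 23%.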

Compound 4, a percentage reported as inhibition, at one concentration (the size of the read-out at that concentration, not a potency): 16.2%
Compound 4: middle estimate off by 7.7 percentage points, on the low side, within the range that was stated.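

In this assay, hydrogen in place of methyl on an oxygen next to a carbonyl group gives a number 7.7 percentage points higher from compound 3 to compound 4 (within the scatter), and set beside the earlier step, the change does not separate the two cores: the same change on two cores in this assay, a number 0.2 percentage points higher (within the scatter) from compound 1 to compound 2 and a number 7.7 percentage points higher (within the scatter) from compound 3 to compound 4, 7.5 percentage points apart, within the scatter of two such steps

Methoxycarbonyl to carboxy therefore carries from one core to the other without a step that stands out from the scatter on either core. This does not show that the two steps are equal, and it rests on two pairs read at a single concentration, so it says nothing about potency.

Open, on these data alone, is how an amide or a longer chain ester, such as ethoxycarbonyl, would read at this place. Also open, as far as these compounds go, is whether the same holds on any further core.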